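A few compounds are considered here, and "the series" means these few. Any claim that something is new, unique, unknown or untested is made for them only; others in the source may bear on it.

Measured so far in a functional assay on HOS cells (Homo sapiens) for antiproliferative activity, read by sulforhodamine B assay; a lower number here means a stronger inhibitor of growth, a higher number a weaker inhibitor of growth:

- compound 1 `CC(C)C[C@@H]1O[C@H](COCc2ccccc2)[C@@H](OCc2ccccc2)[C@H](OCc2ccccc2)[C@H]1O`: 45200 nM
- compound 2 `CC(C)C[C@H]1O[C@H](COCc2ccccc2)[C@@H](OCc2ccccc2)[C@H](OCc2ccccc2)[C@H]1O`: 44500 nM
- compound 3 `CC(C)C[C@@H]1O[C@H](COCc2ccccc2)[C@@H](OCc2ccccc2)[C@H](OCc2ccccc2)[C@@H]1O`: 26300 nM

Compound 1 stands level with the other two, since all three values lie within the usual scatter of one another.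

Compound 4 `O[C@@H]1[C@@H](OCc2ccccc2)[C@H](OCc2ccccc2)[C@@H](COCc2ccccc2)O[C@H]1c1ccccc1` shares the core of compound 1 but has phenyl in place of isobutyl on a saturated ring carbon, next to the ring oxygen: phenyl in place of isobutyl on a saturated ring carbon.

The measured steps bear on this change only indirectly, as they alter configuration and leave the group untouched. They are a 1.0-fold lower number from compound 1 to compound 2 (0.01 log units; within the scatter), a 1.7-fold lower number from compound 1 to compound 3 (0.24 log units; within the scatter) and a 1.7-fold lower number from compound 2 to compound 3 (0.23 log units; within the scatter). Among these three compounds, then, changing configuration at ring carbons gave no step beyond the scatter. Within the data shown here, no measured compound carries phenyl at this place, so the swap itself is untested, and the range has to stay wide.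

The expectation therefore rests on the level set by compound 1 at 45200 nM and compound 3 at 26300 nM, with no step beyond the scatter foreseen. The expected step is a 1.4-fold lower number from compound 1 to compound 4 (0.15 log units; within the scatter).

For compound 4 the estimated value is 32000 nM, with an expected range from 13000 nM to 75000 nM.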

Compound 4, concentration for 50% growth inhibition: > 50000 nM
Compound 4 ended at the assay's limit; the forecaster's own chance of this, stated with the estimate: 15%; middle value at least 1.5-fold (0.19 log units) from the limit.
By their numbers in this assay, from the lowest: compounds 3, 2 and 1 (each within the scatter of the next). At a limit, above all of these: compound 4.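

In this assay compound 4 gives > 50000 nM, which is a limit of the assay and not a number. Among these compounds, the earlier compounds changed only configuration, whereas this is the first change to the group itself, and phenyl in place of isobutyl on this saturated ring carbon, next to the ring oxygen, brings no sign of stronger growth inhibition, the step being an at least 1.1-fold higher number from compound 1 to compound 4 (0.04 log units; that floor lies within the scatter). On these data alone, that floor lies within the scatter, so the data do not establish that phenyl weakens growth inhibition relative to isobutyl, and the real size of the step stays unknown because the reading stops at a ceiling: the limit of > 50000 nM in this assay, at which 1 of the 4 values shown sits.

Still open, as far as these compounds go, is whether a different group on this carbon, such as an aminomethyl group, a carboxylic acid or a longer chain like n-hexyl, would move the number beyond the scatter in either direction. Also open, from the compounds shown here alone, is whether phenyl would read the same with the ring configurations drawn in compound 2 and compound 3, where isobutyl showed no step beyond the scatter.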